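Methoxy for methyl: expected effect on cytotoxicity

The source may report more compounds than this note shows. Statements on the series, on what has been measured and on what is new or still open speak of the compounds shown alone.

In an ADME assay on CHO-K1 cells (Cricetulus griseus) for cytotoxicity, read by MTT assay, with a stated time of 24 h (a lower number here means a stronger inhibitor, a higher number a weaker inhibitor), compound 1 `O=[N+]([O-])c1cc(-c2nnnn2Cc2ccccc2)cc([N+](=O)[O-])c1` gives 18000 nM. Compound 2 `Cc1ccc(Cn2nnnc2-c2cc([N+](=O)[O-])cc([N+](=O)[O-])c2)cc1` gives 28000 nM in this assay, the higher of the two numbers shown, though the step of a 1.6-fold higher number from compound 1 to compound 2 (0.19 log units; within the scatter) is within the scatter. Compound 3 `COc1ccc(Cn2nnnc2-c2cc([N+](=O)[O-])cc([N+](=O)[O-])c2)cc1` carries the change (methoxy in place of methyl on an aromatic carbon). Within the data shown here, the one measured step that bears on this change is a 1.6-fold higher number from compound 1 to compound 2 (0.19 log units; within the scatter), within the scatter, and nothing measured separates methoxy from methyl here. The step from compound 2 to compound 3 is therefore expected to stay within the scatter, a 1.1-fold lower number from compound 2 to compound 3 (0.05 log units; within the scatter). Compound 3 is expected to give 25000 nM in this assay, in a range of 10000 nM to 60000 nM.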

Compound 3, half-maximal inhibitory concentration: 21000 nM
Compound 3: the middle estimate sits 1.2-fold (0.08 log units) above what was measured; the range from low to high includes it.
By their numbers in this assay, from the lowest: compounds 1, 3 and 2 (each within the scatter of the next).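

In this assay, 4-methoxyphenyl does not separate from 4-methylphenyl: a 1.3-fold lower number from compound 2 to compound 3 (0.12 log units; within the scatter). Methoxy in place of hydrogen at this position, para to a large group, reads the same way, a 1.2-fold higher number from compound 1 to compound 3 (0.07 log units; within the scatter), so with methoxy as well as methyl, a substituent here has yet to give a step beyond the scatter. No measurement at hand explains these numbers.

As far as these compounds go, whether an amine, a carboxylic acid or a longer chain at this position would give a step beyond the scatter remains open. So does whether this reading would hold on a different core.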